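A few compounds are considered here, and "the series" means these few. Any claim that something is new, unique, unknown or untested is made for them only; others in the source may bear on it.

Three compounds share one core and differ only in the group carried on an aromatic carbon of it. Compound 1 `CCCCc1nc(N)c2nc(O)n(Cc3ccccc3)c2n1` carries a butyl group, and in a functional assay (spleen, spleen) for activation, with Mus musculus as the target (a lower number here means that less compound is needed, a higher number that more compound is needed for the effect), compound 1 gives 0.03 uM. Compound 2 `Nc1nc(SCc2ccccc2)nc2c1nc(O)n2Cc1ccccc1` carries a benzylsulfanyl group and gives 0.1 uM. Compound 3 `CCCCSc1nc(N)c2nc(O)n(Cc3ccccc3)c2n1` carries a butylsulfanyl group and gives 0.01 uM, the lowest of the three numbers. The steps leading to it were a 3.0-fold lower number from compound 1 to compound 3 (0.48 log units; beyond the scatter) and a 10-fold lower number from compound 2 to compound 3 (1.00 log units; beyond the scatter), while a 3.3-fold higher number from compound 1 to compound 2 (0.52 log units; beyond the scatter).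

Compound 4 `CCCCCOc1nc(N)c2nc(O)n(Cc3ccccc3)c2n1` has not yet been measured. It differs from compound 3 in one place: pentyloxy in place of butylsulfanyl on an aromatic carbon. Both earlier steps onto compound 3 touched the same sulfur-bearing group, one adding a sulfur to a chain of similar length and the other shortening what hangs on the sulfur; neither swaps the sulfur for an oxygen, so they set the scale of effect but give no direction. Since each was modest, a modest step is expected here too, if any beyond the scatter. The estimate for compound 4 is 0.03 uM, within 0.01 uM to 0.1 uM. That expected outcome corresponds to a 3.0-fold higher number from compound 3 to compound 4 (0.48 log units; beyond the scatter).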

Compound 4, minimum effective concentration: 0.01 uM
For compound 4 the middle estimate is 3.0-fold (0.48 log units) above the measured one; the range from low to high includes it.
By their numbers in this assay, from the lowest: compounds 3 and 4 (each within the scatter of the next); then compound 1; then compound 2.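

In this assay, the pentyloxy group in place of butylsulfanyl gives no readable change (no change at the digits printed from compound 3 to compound 4 (within the scatter)), so on this aromatic carbon, between two ring nitrogen atoms, a sulfur-linked chain is not required for the lowest numbers in this set. The pentyloxy group also keeps the gap to the plain butyl group (a 3.0-fold lower number from compound 1 to compound 4 (0.48 log units; beyond the scatter)) and to the benzylsulfanyl group (a 10-fold lower number from compound 2 to compound 4 (1.00 log units; beyond the scatter)), and those gaps match the ones seen for compound 3. Nothing measured here explains why the two groups match.

This change swaps the linking atom and alters the chain at once, so a butyloxy or pentylsulfanyl group would be needed to tell the two apart. As far as these compounds go, it also remains open whether a nitrogen-linked chain, such as a butylamino group, would give the same number.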